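The source may report more compounds than this note shows. Statements on the series, on what has been measured and on what is new or still open speak of the compounds shown alone.

Compound 2 `O=C(O)c1cccc(Cc2c(-c3ccccc3)nn3cc(F)ccc23)n1` sits second highest of the three numbers in a functional assay on cells for antagonist activity at prostaglandin E2 receptor EP1 subtype (Rattus norvegicus), read by fluorescence and calcium flux, with a stated time of 60 s (on this read-out higher numbers stand for weaker inhibition and lower numbers for stronger inhibition), giving 380 nM. Its neighbours are compound 1 `O=C(O)c1cccc(Cc2c(-c3ccccc3)nn3ccccc23)n1`, with 2300 nM, and compound 3 `O=C(O)c1cccc(Cc2c(-c3ccccc3)nn3cc(Br)ccc23)n1`, with 11 nM. The measured steps move in one direction: a 6.1-fold lower number from compound 1 to compound 2 (0.78 log units; beyond the scatter) is modest, while a 210-fold lower number from compound 1 to compound 3 (2.32 log units; beyond the scatter) and a 35-fold lower number from compound 2 to compound 3 (1.54 log units; beyond the scatter) are large. Compound 4 `CS(=O)(=O)c1ccc2c(Cc3cccc(C(=O)O)n3)c(-c3ccccc3)nn2c1` arises from compound 2 by methylsulfonyl in place of fluoro on an aromatic carbon. Within the data shown here, no measured step covers a group of this kind at that carbon, so the bromo steps are the only guide, and a gain in this assay is expected, though smaller than a 35-fold lower number from compound 2 to compound 3 (1.54 log units; beyond the scatter). Compound 4 is therefore estimated at 120 nM, between 15 nM and 900 nM, meaning an expected step of a 3.2-fold lower number from compound 2 to compound 4 (0.50 log units; beyond the scatter).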

Compound 4, half-maximal inhibitory concentration: 5400 nM
For compound 4 the middle estimate is 45-fold (1.65 log units) below the measured one; measured number above the stated range.
By their numbers in this assay, from the lowest: compound 3; then compound 2; then compound 1; then compound 4.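

At this carbon, para to a fused ring, a substituent can also raise the number in this assay: methylsulfonyl in place of hydrogen gives a 2.3-fold higher number from compound 1 to compound 4 (0.37 log units; beyond the scatter), against the lower numbers seen with fluoro and bromo. Set against those two groups, the loss is large, at a 14-fold higher number from compound 2 to compound 4 (1.15 log units; beyond the scatter) and a 490-fold higher number from compound 3 to compound 4 (2.69 log units; beyond the scatter), so the gains do not extend to every group placed here. Nothing available explains this reversal. As far as these compounds go, whether chloro, methyl or methoxy at this carbon would follow bromo or methylsulfonyl remains open. So does how methylthio, which lacks the two sulfonyl oxygens, would compare.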